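Phenoxythiocarbonyl in Place of Benzoyl on the Thiourea Nitrogen

The source may report more compounds than this note shows. Statements on the series, on what has been measured and on what is new or still open speak of the compounds shown alone.

Compound 2 `O=C(NC(=S)N1CCc2c(OCCCCCOc3ccc(Cl)cc3)cccc21)c1ccc(C(F)(F)F)cc1` shares its core with compound 1 `NC(=S)N1CCc2c(OCCCCCOc3ccc(Cl)cc3)cccc21` and compound 3 `COc1ccc(C(=O)NC(=S)N2CCc3c(OCCCCCOc4ccc(Cl)cc4)cccc32)cc1`. In an ADME assay on Huh-7 cells (Homo sapiens) for cytotoxicity (on this read-out lower numbers stand for higher toxicity in this test and higher numbers for lower toxicity in this test), compound 2 gives 32700 nM. Compound 3 gives 34400 nM in this assay, and the two numbers sit within the scatter of each other, the difference being a 1.1-fold higher number from compound 2 to compound 3 (0.02 log units; within the scatter). In this assay compound 1 gives > 50000 nM, which is a limit of the assay and not a number. Compound 1 thus sits at the limit of > 50000 nM in this assay, at which 1 of the 3 values shown sits.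

Compound 4 `S=C(NC(=S)N1CCc2c(OCCCCCOc3ccc(Cl)cc3)cccc21)Oc1ccccc1` has not yet been measured in this assay. It differs from compound 2 in one place: a group of 9 heavy atoms (7 carbon, 1 oxygen, 1 sulfur; one six-membered aromatic ring of carbon only) in place of a group of 12 heavy atoms (8 carbon, 1 oxygen, 3 fluorine; one six-membered aromatic ring of carbon only), on an amide-type nitrogen.

Within the data shown here, three measured steps bear on this change. Adding a (4-(trifluoromethyl)phenyl)carbonyl to the amide-type nitrogen gave an at least 1.5-fold lower number from compound 1 to compound 2 (0.18 log units; that floor lies within the scatter), adding a (4-methoxyphenyl)carbonyl gave an at least 1.4-fold lower number from compound 1 to compound 3 (0.16 log units; that floor lies within the scatter), and exchanging trifluoromethyl for methoxy gave a 1.1-fold higher number from compound 2 to compound 3 (0.02 log units; within the scatter). None of these reaches beyond the scatter, and none involves the group that enters in compound 4. Within this small set, substituents on that nitrogen have not moved the numbers in this assay by more than the scatter, so no step beyond the scatter is expected from compound 2 to compound 4.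

Compound 4 is therefore estimated to give 30000 nM in this assay, with a range from 12000 nM to 60000 nM. That estimate means an expected 1.1-fold lower number from compound 2 to compound 4 (0.04 log units; within the scatter).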

Compound 4, half-maximal cytotoxic concentration: > 50000 nM
Compound 4 ended at the assay's limit (the forecaster's own chance of this, stated with the estimate: 25%); middle value at least 1.6-fold (0.22 log units) from the limit.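

Compound 4 carries an aromatic group on the amide-type nitrogen, as compound 2 and compound 3 do, yet its value in this assay is a limit of the assay and not a number, so a substituent on that nitrogen does not by itself bring a measurable number. Compound 4 now shares that limit with compound 1, which has only hydrogen on this nitrogen: the limit of > 50000 nM in this assay, at which 2 of the 4 values shown sit. The readable steps are an at least 1.5-fold higher number from compound 2 to compound 4 (0.18 log units; that floor lies within the scatter) and an at least 1.4-fold higher number from compound 3 to compound 4 (0.16 log units; that floor lies within the scatter), so the phenoxythiocarbonyl group is not shown to separate from either carbonyl-linked group by more than the scatter, and the step that links compound 4 to compound 1 cannot be read, as both values are limits.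

The compounds shown leave open whether a phenoxycarbonyl group, with oxygen in place of the sulfur, or an unsubstituted benzoyl group on the same nitrogen would also reach the limit. Also open, as far as these compounds go, are how an amine or a carboxylic acid on the aromatic ring of the entering group would read in this assay, and whether any change on this nitrogen can give a step beyond the scatter.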